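Dimethylation of the sulfonamide nitrogen in compound 3

The source may report more compounds than this note shows. Statements on the series, on what has been measured and on what is new or still open speak of the compounds shown alone.

This series shares a core carrying a bromofluorophenyl amidoxime, and the compounds differ in the group attached to the ring nitrogen. Compound 3 `NS(=O)(=O)CCCNc1nonc1/C(=N/O)Nc1ccc(F)c(Br)c1` gives 15 nM in an assay on HeLa cells for inhibition of Indoleamine 2,3-dioxygenase 1 (Homo sapiens), read by spectrophotometry, with a stated time of 24 h (a higher number here means that more compound is needed for the effect, a lower number that less compound is needed), the lowest of the three numbers. Compound 1 `O=S1(=O)CC(Nc2nonc2/C(=N/O)Nc2ccc(F)c(Br)c2)C1` gives 59 nM, and compound 2 `O=S(=O)(CCNc1nonc1/C(=N/O)Nc1ccc(F)c(Br)c1)NCC1CC1` gives 268 nM. The step of a 3.9-fold lower number from compound 1 to compound 3 (0.59 log units; beyond the scatter) and the step of an 18-fold lower number from compound 2 to compound 3 (1.25 log units; beyond the scatter) both place compound 3 ahead of its neighbours.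

Compound 4 `CN(C)S(=O)(=O)CCCNc1nonc1/C(=N/O)Nc1ccc(F)c(Br)c1` is the next case: dimethylamino in place of amino on a sulfonyl sulfur. The step from compound 2 to compound 3 bears most directly on this change, since it also concerns what sits on the sulfonamide nitrogen; there, replacing a substituted sulfonamide with the free one gave an 18-fold lower number from compound 2 to compound 3 (1.25 log units; beyond the scatter). For the measured compounds named here, the change from compound 3 to compound 4 goes the other way, capping the nitrogen with two methyl groups, though the group added is smaller than the one removed in compound 2. A higher number in this assay is therefore expected for compound 4, of a size that could be modest or larger.

Compound 4 is expected at 80 nM, within 25 nM to 300 nM, an expected step of a 5.3-fold higher number from compound 3 to compound 4 (0.73 log units; beyond the scatter).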

Compound 4, half-maximal effective concentration: 20 nM
Compound 4: middle estimate off by 4.0-fold (0.60 log units), on the high side; measured number below the stated range.
By their numbers in this assay, from the lowest: compounds 3 and 4 (each within the scatter of the next); then compound 1; then compound 2.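

In this assay, the step of a 1.3-fold higher number from compound 3 to compound 4 (0.12 log units; within the scatter) shows that amino on this sulfonyl sulfur can give way to dimethylamino, losing the hydrogen-bond donor of amino, with no difference that can be told from the scatter. Compound 4 also keeps the clear lead of compound 3 over its other neighbours, with a 13-fold lower number from compound 2 to compound 4 (1.13 log units; beyond the scatter) and a 3.0-fold lower number from compound 1 to compound 4 (0.47 log units; beyond the scatter), so a substituted sulfonamide nitrogen does not in itself go with a higher number here, although compound 2, which also differs in its chain, remains the high case. No measurement shown here bears on why amino and dimethylamino give such similar numbers.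

The compounds shown leave open whether a single methyl on this nitrogen, or the cyclopropylmethyl group of compound 2 carried on the chain of compound 3, would also stay within the scatter of compound 3. They also leave open how far the number would hold with a morpholine ring on the sulfonyl sulfur, or with a carboxylic acid in place of the whole sulfonamide.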